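Amide variation on two dihydroxyphenyl thiadiazole cores

The source may report more compounds than this note shows. Statements on the series, on what has been measured and on what is new or still open speak of the compounds shown alone.

Compound 1 `O=C(Nc1nnc(-c2cccc(O)c2O)s1)c1ccc(Cl)cc1` and compound 2 `O=C(Nc1nnc(-c2ccc(O)c(O)c2)s1)c1ccc(Cl)cc1` share the same atoms joined differently; the difference between the two cores is not broken down here. In a functional assay on HL-60 cells (Homo sapiens) for cytotoxicity, read by MTT assay, with a stated time of 72 h (a lower number here means a stronger inhibitor, a higher number a weaker inhibitor), compound 1 gives 9600 nM and compound 2 gives 14700 nM, two values within the usual scatter of each other. Compound 3 `CC(=O)Nc1nnc(-c2cccc(O)c2O)s1` carries the change methyl in place of 4-chlorophenyl on a carbonyl carbon on the core of compound 1. In this assay compound 3 gives 49000 nM, so that a 5.1-fold higher number from compound 1 to compound 3 (0.71 log units; beyond the scatter). Compound 4 `CC(=O)Nc1nnc(-c2ccc(O)c(O)c2)s1` carries the same kind of change, (methyl in place of 4-chlorophenyl on a carbonyl carbon), on the core of compound 2; the place is described in the same words for both changes. Only the one measured step is available as a guide, and nothing beyond the compounds shown supports it. On that basis the step from compound 2 to compound 4 is expected to be a 4.8-fold higher number from compound 2 to compound 4 (0.68 log units; beyond the scatter), resting on the measured step from compound 1 to compound 3. Compound 4 is estimated at 70000 nM in this assay, with an expected range from 30000 nM to 160000 nM.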

Compound 4, half-maximal inhibitory concentration: 42500 nM
Compound 4: the middle estimate sits 1.6-fold (0.22 log units) above what was measured; the measured number falls inside the stated range.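

Methyl in place of 4-chlorophenyl on a carbonyl carbon has now been read on both cores in this assay, and the new step is a 2.9-fold higher number from compound 2 to compound 4 (0.46 log units; beyond the scatter). Set beside the earlier step, the change goes the same way on both cores and the two sizes cannot be told apart: the same change on two cores in this assay, a 5.1-fold higher number (0.71 log units; beyond the scatter) from compound 1 to compound 3 and a 2.9-fold higher number (0.46 log units; beyond the scatter) from compound 2 to compound 4, 1.8-fold (0.25 log units) apart, within the scatter of two such steps. This shows that the change carried over between these two cores, but it rests on two pairs in a single assay and does not show that it would carry to any other core or hold for any other group in that place.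

Only methyl and 4-chlorophenyl stand on the carbonyl carbon in the compounds shown, which leaves open whether the higher numbers go with the loss of the ring, of the chlorine or of the size of the group as a whole. Unsubstituted phenyl, a longer chain such as n-butyl or a group carrying an amine in the same place would begin to separate these readings.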